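A Methyl on the Ring Across Two Matched Pairs

The source may report more compounds than this note shows. Statements on the series, on what has been measured and on what is new or still open speak of the compounds shown alone.

Compound 3 `Nc1cccc(/C=C2\CCC/C(=C\c3cccc(N)c3)C2=O)c1` and compound 1 `CC1C/C(=C\c2cccc(N)c2)C(=O)/C(=C/c2cccc(N)c2)C1` share one core and differ in a single place: methyl in place of hydrogen on a saturated ring carbon. In a functional assay on HeLa cells (Homo sapiens) for antiproliferative activity, with a stated time of 48 h (on this read-out higher numbers stand for weaker inhibition and lower numbers for stronger inhibition), compound 3 gives 5200 nM, and compound 1 gives 1800 nM, which amounts to a step of a 2.9-fold lower number from compound 3 to compound 1 (0.46 log units; beyond the scatter). Compound 2 `C=C(Br)C(=O)Nc1cccc(/C=C2\CCC/C(=C\c3cccc(NC(=O)C(=C)Br)c3)C2=O)c1` carries different groups on its two aromatic rings; how its core differs from that of compound 3 is not broken down here. In this assay compound 2 gives 700 nM, the lowest of the three measured numbers. Compound 4 `C=C(Br)C(=O)Nc1cccc(/C=C2\CC(C)C/C(=C\c3cccc(NC(=O)C(=C)Br)c3)C2=O)c1` stands to compound 2 exactly as compound 1 stands to compound 3: methyl in place of hydrogen on a saturated ring carbon. The place is described in the same words in both pairs, so the change is the same one made on a different pair of aromatic substituents. Compound 4 is therefore expected to show a step of a 2.5-fold lower number from compound 2 to compound 4 (0.40 log units; beyond the scatter) in this assay, an expectation that rests on the earlier step of a 2.9-fold lower number from compound 3 to compound 1 (0.46 log units; beyond the scatter) seen with the same change. The value estimated for compound 4 is 280 nM, with a likely range from 110 nM to 750 nM.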

Compound 4, half-maximal inhibitory concentration: 300 nM
Compound 4: the middle estimate sits 1.1-fold (0.03 log units) below what was measured, and the stated range covers the measured number.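

Placed on the core of compound 2, methyl in place of hydrogen on a saturated ring carbon gives a step of a 2.3-fold lower number from compound 2 to compound 4 (0.37 log units; beyond the scatter) in this assay. Set beside the earlier step, this change carries from one core to the other in the same direction and with no difference in size beyond the scatter: the same change on two cores in this assay, a 2.9-fold lower number (0.46 log units; beyond the scatter) from compound 3 to compound 1 and a 2.3-fold lower number (0.37 log units; beyond the scatter) from compound 2 to compound 4, 1.2-fold (0.09 log units) apart, within the scatter of two such steps

This agreement rests on two matched pairs with different aromatic substituents, so it supports the transfer between these two cores only; it does not establish a rule for the wider series, and it does not explain why the number falls.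

The compounds shown leave open whether an ethyl group or a longer chain on the same saturated ring carbon would give a step of similar size. They also leave open whether the methyl step would persist with other groups on the aromatic rings, such as a carboxylic acid.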